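The source may report more compounds than this note shows. Statements on the series, on what has been measured and on what is new or still open speak of the compounds shown alone.

Compound 1 `COc1ccc(-c2cc(/C=C/C(=O)c3ccc(N)cc3)[nH]n2)cc1` and compound 2 `COc1cc(-c2cc(/C=C/C(=O)c3ccc(N)cc3)[nH]n2)cc(OC)c1OC` have both been run in a functional assay on SK-MEL-5 cells (Homo sapiens) for cytotoxicity, read by sulforhodamine B assay, with a stated time of 48 h, tested at 1 uM; on this read-out lower numbers stand for a stronger effect and higher numbers for a weaker effect at the one concentration tested. In this assay compound 1 gives 90%. In this assay compound 2 gives 90%, level with compound 1 at the digits shown, so the two sit within the usual scatter of each other and no order between them can be read. Compound 3 `COc1ccc(-c2cc(/C=C/C(=O)c3ccc(N)cc3)[nH]n2)cc1OC` has not yet been measured in this assay. Against compound 2 the change is hydrogen in place of methoxy on an aromatic carbon. Among the compounds with values here, no step between measured compounds exists to size this change; what compound 1 and compound 2 show is one common level, and compound 3 stands structurally within the span covered by those two. The step expected in this assay is none beyond the scatter, estimated as no change at the digits printed from compound 2 to compound 3 (within the scatter). Compound 3 is expected to give about 90%, in a range from 78% to 100%.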

Compound 3, a percentage reported as activity, at one concentration (the size of the read-out at that concentration, not a potency): 94%
Estimate against measurement, compound 3: 4 percentage points below, and the stated range covers the measured number.
By their numbers in this assay, from the lowest: compounds 1, 2 and 3 (each within the scatter of the next).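

The step of a number 4 percentage points higher from compound 2 to compound 3 (within the scatter) comes with hydrogen in place of methoxy on an aromatic carbon, and the step of a number 4 percentage points higher from compound 1 to compound 3 (within the scatter) comes with methoxy in place of hydrogen on an aromatic carbon. Within the data shown here, these are the first single-place comparisons, and in this assay neither exchange moves the read-out beyond the scatter, so this carbon of the methoxy-bearing ring tolerates either group at the one concentration tested. No measurement shown here bears on why the read-out stays level.

On these data alone, whether a hydroxyl group, an amine or a carboxylic acid on this aromatic carbon would shift the read-out remains open. All three compounds also sit at the weak end of this single-concentration read-out, so any difference that would show only at higher concentrations remains unresolved.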